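One Methoxy Fewer: Expected Cytotoxicity of Compound 3

The source may report more compounds than this note shows. Statements on the series, on what has been measured and on what is new or still open speak of the compounds shown alone.

Compound 1, `COc1ccc(-c2cc(/C=C/C(=O)c3ccc(N)cc3)[nH]n2)cc1`: 100%
Compound 2, `COc1cc(-c2cc(/C=C/C(=O)c3ccc(N)cc3)[nH]n2)cc(OC)c1OC`: 92%

Of the compounds shown here, two have been tested in a functional assay on HOP-62 cells (Homo sapiens) for cytotoxicity, read by sulforhodamine B assay, with a stated time of 48 h, tested at 0.1 uM; a lower number here means a stronger effect, a higher number a weaker effect of the compound at the concentration tested. Compound 1, `COc1ccc(-c2cc(/C=C/C(=O)c3ccc(N)cc3)[nH]n2)cc1`, gives 100% there, and compound 2, `COc1cc(-c2cc(/C=C/C(=O)c3ccc(N)cc3)[nH]n2)cc(OC)c1OC`, gives 92% in this assay. Of the two numbers shown compound 2 has the smaller one, but the gap to compound 1 lies within the scatter, so the pair cannot be told apart. Compound 3, `COc1ccc(-c2cc(/C=C/C(=O)c3ccc(N)cc3)[nH]n2)cc1OC`, has not been measured. It differs from compound 2 in one place: hydrogen in place of methoxy on an aromatic carbon. For the measured compounds named here, no step between measured compounds exists to set a size for such a change. The two measured numbers sit together even though the count of methoxy groups differs between them, because compound 1 gives 100% while compound 2 gives 92%. On that basis compound 3 is expected to show a number 4 percentage points higher from compound 2 to compound 3 (within the scatter), no step beyond the scatter. Compound 3 is therefore estimated at 96%, with a range from 84% to 106%.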

Compound 3, a percentage reported as activity, at one concentration (the size of the read-out at that concentration, not a potency): 91%
For compound 3 the middle estimate is 5 percentage points above the measured one; measured number inside the range.
By their numbers in this assay, from the lowest: compounds 3, 2 and 1 (each within the scatter of the next).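

For the compounds shown here, compounds 1 and 2 differ in more than one place, so they set no size for a single methoxy change; compound 3 supplies the first such steps in this assay. On the aromatic carbon ortho to a methoxy group and meta to a large group, hydrogen in place of methoxy gives a number 1 percentage points lower from compound 2 to compound 3 (within the scatter), while the other single change, methoxy in place of hydrogen, gives a number 9 percentage points lower from compound 1 to compound 3 (within the scatter), so neither single methoxy change separates its pair of compounds here. Nothing measured here explains why these numbers sit so close.

On these data alone, it remains open whether a hydroxyl group, an ethoxy group or a fluorine atom on that aromatic carbon would also stay within the scatter. Also open, as far as these compounds go, is whether the three compounds would still read alike at other concentrations.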